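The source may report more compounds than this note shows. Statements on the series, on what has been measured and on what is new or still open speak of the compounds shown alone.

Measured: compound 1 `COc1cccc(OC(=O)c2ccc(O)cc2)c1OC(=O)c1ccc(O)cc1` with 86.5%; compound 2 `O=C(Oc1ccccc1OC(=O)c1ccc(O)cc1)c1ccc(O)cc1` with 57.5%.

In a functional assay on NCI-H1299 cells (Homo sapiens) for inhibition, read by scintillation counting, with a stated time of 30 min, tested at 30 uM (a lower number here means less inhibition, a higher number more inhibition at the concentration tested (going by the name of the read-out)), compound 2 gives 57.5%, the lowest of the two numbers, with compound 1 giving 86.5%. Compound 3 `O=C(Oc1cccc(OC(=O)c2ccc(O)cc2)c1OC(=O)c1ccc(O)cc1)c1ccc(O)cc1` differs from compound 2 by ((4-hydroxyphenyl)carbonyl)oxy in place of hydrogen on an aromatic carbon. Going by the values given here, the only measured step that bears on this, a number 29 percentage points lower from compound 1 to compound 2 (beyond the scatter), shows that removing a group at an aromatic carbon of the shared core lowered inhibition; the group now entering is a different one, so the carry-over is uncertain. A rise in this assay is expected, estimated as a number 17.5 percentage points higher from compound 2 to compound 3 (beyond the scatter). For compound 3 the expected inhibition is 75%, within 50% to 95%.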

Compound 3, a percentage reported as inhibition, at one concentration (the size of the read-out at that concentration, not a potency): 88.7%
Estimate against measurement, compound 3: 13.7 percentage points below; low and high end bracket the measured number.
By their numbers in this assay, from the lowest: compound 2; then compounds 1 and 3 (each within the scatter of the next).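

Putting ((4-hydroxyphenyl)carbonyl)oxy on this aromatic carbon clearly raises inhibition in this assay (a number 31.2 percentage points higher from compound 2 to compound 3 (beyond the scatter)). Exchanging the methyl on that oxygen for (4-hydroxyphenyl)carbonyl shows no measurable change (a number 2.2 percentage points higher from compound 1 to compound 3 (within the scatter)), so among these compounds methoxy and the much larger group both give more inhibition than hydrogen and cannot be told apart. Nothing available explains these results. From the compounds shown here alone, whether the linking oxygen is needed remains open. An amine or an ethyl group on the same carbon would test this.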